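Swapping a carboxypyridine for a carboxyphenyl in a bile acid receptor agonist

This account rests on a few compounds, and the source may have more. Where it says the series, first, only, none or still open, it means among the compounds named here.

Three compounds sharing one core have been examined in an assay on HEK293 cells for agonist activity at Bile acid receptor (Homo sapiens); on this read-out higher numbers stand for an effect only at larger amounts of compound and lower numbers for an effect already at smaller amounts. Compound 1 `O=C(O)CNC(=O)c1ccc(C2CC2c2ccc(OCc3c(-c4c(Cl)cccc4Cl)noc3C3CC3)cc2Cl)cc1` gives 209 nM, compound 2 `CS(=O)(=O)NC(=O)c1ccc([C@@H]2C[C@H]2c2ccc(OCc3c(-c4c(Cl)cccc4Cl)noc3C3CC3)cc2Cl)cc1` gives 44 nM, and compound 3 `O=C(O)c1ccc(C2CC2c2ccc(OCc3c(-c4c(Cl)cccc4Cl)noc3C3CC3)cc2Cl)cn1` gives 57 nM. Among these three, compound 3 holds the second highest number: its nearest neighbour is compound 2, which sits within the usual scatter of this assay, while compound 1 lies furthest away, with a higher number beyond the scatter.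

Compound 4 `O=C(O)c1cccc([C@@H]2C[C@H]2c2ccc(OCc3c(-c4c(Cl)cccc4Cl)noc3C3CC3)cc2Cl)c1` has not been measured yet. It differs from compound 3 in a single region: 2-(3-carboxyphenyl)cyclopropyl in place of 2-(6-carboxypyridin-3-yl)cyclopropyl on an aromatic carbon. The acid group stays, but the ring carrying it loses its nitrogen and the acid moves to a different position on that ring, and the cyclopropyl now has two defined stereocentres.

Within the data shown here, no measured pair in this set shows a change of this exact kind, so the expectation rests on the closeness of compounds 2 and 3 alone. The step expected for compound 4, a 1.4-fold higher number from compound 3 to compound 4 (0.15 log units; within the scatter), is small, likely within the scatter, with no firm direction. Compound 4 is therefore estimated at 80 nM, within a range from 25 nM to 250 nM.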

Compound 4, half-maximal effective concentration: 29 nM
Compound 4: the middle estimate sits 2.8-fold (0.44 log units) above what was measured; measured number inside the range.
By their numbers in this assay, from the lowest: compounds 4, 2 and 3 (each within the scatter of the next); then compound 1.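

Exchanging 2-(6-carboxypyridin-3-yl)cyclopropyl for 2-(3-carboxyphenyl)cyclopropyl on this aromatic carbon, ortho to a chloro group, gives a 2.0-fold lower number from compound 3 to compound 4 (0.29 log units; within the scatter) in this assay. Among these compounds, this is the first direct comparison at this position, and it shows that the ring nitrogen can be lost, the carboxylic acid placed differently and two stereocentres defined, all in one step, without a change beyond the scatter. Nothing measured here explains this result.

From the compounds shown here alone, since these three differences arrive together, the contribution of each one remains unknown, and a small step could hide opposing effects. Going by these compounds, it also remains open whether the ring can carry a nitrile or an amine in place of the carboxylic acid, or whether the opposite arrangement at the cyclopropyl stereocentres gives a similar number.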